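Purine series: removal of the amino group on the core

This account rests on a few compounds, and the source may have more. Where it says the series, first, only, none or still open, it means among the compounds named here.

Measured so far:
compound 1 `ClCc1cccc(Cn2cnc3c(Cl)nc(Cl)nc32)c1`: 2230 nM
compound 2 `Nc1nc(Cl)c2ncn(Cc3ccccc3CCl)c2n1`: 5010 nM

In a functional assay on COLO 205 cells (Homo sapiens) for cytotoxicity, read by sulforhodamine B assay, with a stated time of 48 h (a higher number here means a weaker inhibitor of growth, a lower number a stronger inhibitor of growth), compound 1 gives 2230 nM. In this assay compound 2 gives 5010 nM, the highest of the two numbers; the nearest is compound 1, which sits at a lower number by a gap beyond the scatter. Among the compounds with values here, no single-point step between the two measured compounds exists, since they differ both in the benzyl substitution and in the groups on the core, so what the pair shows is only that compound 1 is the stronger inhibitor of growth of the two.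

Compound 3 `ClCc1ccccc1Cn1cnc2c(Cl)ncnc21` has not yet been measured. It keeps the ortho chloromethyl benzyl of compound 2, and differs from it only in the core: hydrogen in place of amino on an aromatic carbon

With no measured step of this kind in the series, the direction is open. The step expected here, a 1.4-fold lower number from compound 2 to compound 3 (0.16 log units; within the scatter), is taken as small, toward a slightly lower number, and within the scatter. Compound 3 is accordingly estimated at 3500 nM, with a range from 1400 nM to 9000 nM.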

Compound 3, concentration for 50% growth inhibition: 3890 nM
Beside the measured number, compound 3's estimate is 1.1-fold (0.05 log units) below it; low and high end bracket the measured number.
By their numbers in this assay, from the lowest: compounds 1, 3 and 2 (each within the scatter of the next, the first and the last beyond it).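

In this assay, within the data shown here, a 1.3-fold lower number from compound 2 to compound 3 (0.11 log units; within the scatter) is the first single-change step. It shows that, with the chloromethyl benzyl group of compound 2 kept, hydrogen in place of amino on this aromatic carbon between two ring nitrogen atoms leaves the number within the scatter. For this one pair, the amino group at this position is therefore not needed to retain growth inhibition at this level, although a single step within the scatter sets no rule for the series. Nothing measured here bears on why the step is this small.

Compound 1 carries a chloro group on this same carbon but has its chloromethyl group placed differently on the benzyl ring, so the compounds shown do not isolate the effect of chloro against amino or hydrogen. Also open, going by these compounds, is whether a methoxy group or a dimethylamine on this carbon would stay within the scatter of compound 3, and whether the result would hold with the other chloro group on the core replaced by an amine.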